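The source may hold more compounds than are shown below. What is called first, only, known or untested is meant among the compounds shown, and "the series" means these compounds.

Of the compounds shown here, three built on one shared core have been measured in a functional assay on OVCAR-4 cells (Homo sapiens) for inhibition, read by sulforhodamine B assay, with a stated time of 48 h; a higher number here means a weaker inhibitor of growth, a lower number a stronger inhibitor of growth. Compound 1 `Cc1nnc(-c2nn(-c3ccccc3)c(-c3ccccc3)c2C#N)c2cn(-c3ccccc3)nc12` gives 56400 nM, compound 2 `N#Cc1c(-c2nnc(O)c3nn(-c4ccccc4)cc23)nn(-c2ccccc2)c1-c1ccccc1` gives 26400 nM and compound 3 `N#Cc1c(-c2nnc(O)c3nn(-c4ccc(Cl)cc4)cc23)nn(-c2ccccc2)c1-c1ccccc1` gives 4380 nM, so compound 2 holds the middle of the three numbers. Compound 4 `N#Cc1c(-c2nnc(-c3ccccc3)c3nn(-c4ccccc4)cc23)nn(-c2ccccc2)c1-c1ccccc1` has not yet been measured. It differs from compound 2 in one place, with phenyl in place of hydroxy on an aromatic carbon.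

Within the data shown here, two measured steps bear on this change. The closer one concerns the same carbon, where hydroxy in place of methyl gave a 2.1-fold lower number from compound 1 to compound 2 (0.33 log units; beyond the scatter). The other, with chloro in place of hydrogen at a different place in the molecule, gave a 6.0-fold lower number from compound 2 to compound 3 (0.78 log units; beyond the scatter). Both steps are modest, and neither puts a ring on the carbon that changes here, so they fix the direction only weakly. Compound 1, at 56400 nM, has a carbon-linked group on that carbon and the higher number, which hints at a slight rise in this assay. The expected result is a 1.1-fold higher number from compound 2 to compound 4 (0.06 log units; within the scatter), which means no step beyond the scatter. For compound 4 the estimated value is 30000 nM, with an expected range from 9000 nM to 90000 nM.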

Compound 4, concentration for 50% growth inhibition: 63000 nM
Beside the measured number, compound 4's estimate is 2.1-fold (0.32 log units) below it, and the stated range covers the measured number.
By their numbers in this assay, from the lowest: compound 3; then compound 2; then compounds 1 and 4 (each within the scatter of the next).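

In this assay, the first ring placed on this aromatic carbon gives a 2.4-fold higher number from compound 2 to compound 4 (0.38 log units; beyond the scatter) when phenyl replaces hydroxy, so a much larger aromatic group here brings no gain in growth inhibition. The comparison with methyl adds a second point: phenyl in place of methyl gives a 1.1-fold higher number from compound 1 to compound 4 (0.05 log units; within the scatter), so these two carbon-linked groups cannot be told apart here, despite the difference in size between them, and of the three groups seen on this carbon only hydroxy gives a clearly lower number. Hydroxy has a hydrogen-bond donor and a hydrogen-bond acceptor while phenyl has neither, but no measurement available here explains why hydroxy stands apart from phenyl and methyl.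

Still open, as far as these compounds go, is whether an amine or a methoxy group on this carbon would track hydroxy or fall in with methyl and phenyl. Also open, from the compounds shown here alone, is whether the chloro group, which gave a 6.0-fold lower number from compound 2 to compound 3 (0.78 log units; beyond the scatter) on the ring elsewhere in the molecule, would have a similar effect with phenyl rather than hydroxy on this carbon.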